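Methoxy in place of methyl: working notes on the series

The source may report more compounds than this note shows. Statements on the series, on what has been measured and on what is new or still open speak of the compounds shown alone.

In a functional assay on A549 cells (Homo sapiens) for antiproliferative activity, read by MTT assay, with a stated time of 72 h (a lower number here means a stronger inhibitor, a higher number a weaker inhibitor), compound 3 (`Cc1ccc(Nc2cccc3c2S(=O)(=O)C=C3)cc1`) gives 2680 nM and compound 1 (`O=S1(=O)C=Cc2cccc(Nc3ccc(C(F)(F)F)cc3)c21`) gives 2440 nM, two values within the scatter of each other. Compound 2 (`O=S1(=O)C=Cc2cccc(Nc3ccc(Cl)cc3)c21`) gives 1040 nM, a lower number than both.

Compound 4 (`COc1ccc(Nc2cccc3c2S(=O)(=O)C=C3)cc1`) has methoxy in place of methyl on an aromatic carbon, para to a large group: methoxy in place of methyl on an aromatic carbon. Three measured steps at this place bear on it: a 2.3-fold lower number from compound 1 to compound 2 (0.37 log units; beyond the scatter), a 1.1-fold higher number from compound 1 to compound 3 (0.04 log units; within the scatter) and a 2.6-fold higher number from compound 2 to compound 3 (0.41 log units; beyond the scatter). None involves methoxy, and none is more than modest, so no step beyond the scatter is expected in this assay. The expected step is a 1.2-fold lower number from compound 3 to compound 4 (0.09 log units; within the scatter). Compound 4 is estimated at 2200 nM, with an expected range of 1000 nM to 4500 nM.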

Compound 4, half-maximal inhibitory concentration: 2590 nM
The estimate for compound 4 lay 1.2-fold (0.07 log units) below the measured number; the measured number falls inside the stated range.
By their numbers in this assay, from the lowest: compound 2; then compounds 1, 4 and 3 (each within the scatter of the next).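

In this assay methoxy on this aromatic carbon, para to a large group, adds no step beyond the scatter against methyl (a 1.0-fold lower number from compound 3 to compound 4 (0.01 log units; within the scatter)) or trifluoromethyl (a 1.1-fold higher number from compound 1 to compound 4 (0.03 log units; within the scatter)). Only chloro stands apart from methoxy (a 2.5-fold higher number from compound 2 to compound 4 (0.40 log units; beyond the scatter)), as it does from the other two groups, so compound 2 alone holds a lower number among the four compounds. No measurement at hand accounts for this separation.

Open, on these data alone, is whether bromo or fluoro would share the number of chloro at this place. Also open, as far as these compounds go, is whether an amine, a carboxylic acid or a longer chain would move the number beyond the scatter.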